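Chloro on the pyridine ring of vinyl sulfone activators

The source may report more compounds than this note shows. Statements on the series, on what has been measured and on what is new or still open speak of the compounds shown alone.

Compound 1 `O=S(=O)(/C=C/c1ccccn1)c1ccccc1F` is the reference. In an assay on U2OS cells for activation of nuclear factor erythroid 2-related factor 2 (Homo sapiens), read by beta-arrestin recruitment, with a stated time of 6 h (on this read-out lower numbers stand for an effect already at smaller amounts and higher numbers for an effect only at larger amounts of compound), compound 1 gives 1050 nM. Compound 2 `O=S(=O)(/C=C/c1ccc(Cl)cn1)c1ccccc1F` differs by chloro in place of hydrogen on an aromatic carbon and in this assay compound 2 gives 1040 nM; that move is a 1.0-fold lower number from compound 1 to compound 2 (0.00 log units; within the scatter). Compound 3 `O=S(=O)(/C=C/c1ccccn1)c1ccc(Cl)cc1` carries a different core, and the difference between the two cores is not broken down here; in this assay compound 3 gives 1730 nM.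

Compound 4 `O=S(=O)(/C=C/c1cccc(Cl)n1)c1ccc(Cl)cc1` is not yet measured. It differs from compound 3 by chloro in place of hydrogen on an aromatic carbon, the same kind of change as chloro in place of hydrogen on an aromatic carbon, though the entering group sits next to the ring nitrogen and meta to a large group rather than two atoms from the ring nitrogen and para to a large group. Because a 1.0-fold lower number from compound 1 to compound 2 (0.00 log units; within the scatter) was flat, the expected step is a 1.0-fold lower number from compound 3 to compound 4 (0.01 log units; within the scatter). Compound 4 is estimated to give 1700 nM, between 800 nM and 3600 nM.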

Compound 4, half-maximal effective concentration: 1460 nM
Estimate against measurement, compound 4: 1.2-fold (0.07 log units) above, and the stated range covers the measured number.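

In this assay, chloro in place of hydrogen on an aromatic carbon gives a 1.2-fold lower number from compound 3 to compound 4 (0.07 log units; within the scatter), so the change is as flat on the second core as on the first: the same change on two cores in this assay, a 1.0-fold lower number (0.00 log units; within the scatter) from compound 1 to compound 2 and a 1.2-fold lower number (0.07 log units; within the scatter) from compound 3 to compound 4, 1.2-fold (0.07 log units) apart, within the scatter of two such steps

This shows that, on these two cores, the change leaves the number within the scatter. It does not show that a single placement carries across, as the chloro in compound 4 sits next to the ring nitrogen and meta to a large group while the chloro in compound 2 sits elsewhere, so core and place vary together.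

On these data alone, it remains open whether an amine or a carboxylic acid on the six-membered aromatic ring with 1 nitrogen would move the number beyond the scatter on either core.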